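Chloro Addition on a Hydroquinone-Bearing Pyrazole Scaffold

This account rests on a few compounds, and the source may have more. Where it says the series, first, only, none or still open, it means among the compounds named here.

Measured so far:
compound 1, `Oc1ccc(O)c(-c2cc(-c3ccccc3)nn2-c2ccccc2)c1`, 26900 nM
compound 2, `Oc1ccc(O)c(-c2cc(-c3ccc(Cl)cc3)nn2-c2ccccc2)c1`, 6850 nM
compound 3, `CC(=O)NS(=O)(=O)c1ccc(-n2nc(-c3ccccc3)cc2-c2cc(O)ccc2O)cc1`, 93900 nM

Of the compounds shown here, three sharing one core have been tested in a functional assay on cells (Cancer cell lines, Homo sapiens) for cytotoxicity, read by sulforhodamine B assay, with a stated time of 48 h; a lower number here means a stronger inhibitor of growth, a higher number a weaker inhibitor of growth. Compound 1 carries an unsubstituted phenyl on each side of the core. Compound 2 differs from it by chloro in place of hydrogen on an aromatic carbon, and the step of a 3.9-fold lower number from compound 1 to compound 2 (0.59 log units; beyond the scatter) goes toward a stronger inhibitor of growth. Compound 3 differs from compound 1 by acetylsulfamoyl in place of hydrogen on an aromatic carbon, and here the step of a 3.5-fold higher number from compound 1 to compound 3 (0.54 log units; beyond the scatter) goes the other way, leaving compound 3 with the highest number of the three.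

Compound 4, `CC(=O)NS(=O)(=O)c1ccc(-n2nc(-c3ccc(Cl)cc3)cc2-c2cc(O)ccc2O)cc1`, has not yet been measured. It differs from compound 3 by chloro in place of hydrogen on an aromatic carbon, which is the same change that turns compound 1 into compound 2, placed on the same kind of aromatic carbon, and the two cores differ only as described for compound 3 against compound 1. Because the earlier step of a 3.9-fold lower number from compound 1 to compound 2 (0.59 log units; beyond the scatter) lay beyond the scatter, compound 4 is expected to show a step of similar direction and size, roughly a 3.8-fold lower number from compound 3 to compound 4 (0.57 log units; beyond the scatter), in this assay. The estimate for compound 4 is therefore 25000 nM, with a plausible range from 10000 nM to 70000 nM, still weaker than compound 2 given the high starting number of compound 3.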

Compound 4, concentration for 50% growth inhibition: 36200 nM
Beside the measured number, compound 4's estimate is 1.4-fold (0.16 log units) below it, and the stated range covers the measured number.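

In this assay, phenyl to 4-chlorophenyl on the core bearing acetylsulfamoyl gives a 2.6-fold lower number from compound 3 to compound 4 (0.41 log units; beyond the scatter), so the change keeps its direction on this second core, and its size there does not differ from that on the core of compound 1: the same change on two cores in this assay, a 3.9-fold lower number (0.59 log units; beyond the scatter) from compound 1 to compound 2 and a 2.6-fold lower number (0.41 log units; beyond the scatter) from compound 3 to compound 4, 1.5-fold (0.18 log units) apart, within the scatter of two such steps The acetylsulfamoyl change reads the same way on the chlorinated core, where it gives a 5.3-fold higher number from compound 2 to compound 4 (0.72 log units; beyond the scatter), and this step also matches its counterpart: the same change on two cores in this assay, a 3.5-fold higher number (0.54 log units; beyond the scatter) from compound 1 to compound 3 and a 5.3-fold higher number (0.72 log units; beyond the scatter) from compound 2 to compound 4, 1.5-fold (0.18 log units) apart, within the scatter of two such steps Together the four compounds show that, within this one set, the two changes add up with no detectable dependence on each other, but they rest on a single closed square of compounds and do not show that this would hold on a core further removed, or why either change moves the number.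

The compounds shown leave open whether a fluoro, methoxy or trifluoromethyl group in place of chloro would carry across the two cores in the same way. They also leave open whether a free sulfonamide or a carboxylic acid in place of acetylsulfamoyl, or methoxy groups in place of the hydroxyl groups, would keep these steps unchanged.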